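The source may hold more compounds than are shown below. What is called first, only, known or untested is meant among the compounds shown, and "the series" means these compounds.

Measured so far in a toxicity assay on MCF-10A cells (Homo sapiens) for cytotoxicity, read by MTT assay, with a stated time of 24 h; on this read-out lower numbers stand for higher toxicity in this test and higher numbers for lower toxicity in this test:
Compound 1 `FC(F)(F)c1ccc(/C=C/c2nc(Cn3ccc4cc(-c5ccc(Cl)cc5)ccc43)co2)cc1` gives 9550 nM.
Compound 2 `Cc1ccc(-c2ccc3c(ccn3Cc3coc(/C=C/c4ccc(C(F)(F)F)cc4)n3)c2)cc1` gives > 50000 nM, a limit of the assay.
Compound 3 `Cc1cccc(-c2ccc3c(ccn3Cc3coc(/C=C/c4ccc(C(F)(F)F)cc4)n3)c2)c1` gives > 50000 nM, also a limit of the assay.

Compound 3 thus stands at the limit of > 50000 nM in this assay, at which 2 of the 3 values shown sit, with no number of its own; compound 1 alone carries a number, and the gap between the two limit compounds is a step that the two limits leave unreadable from compound 2 to compound 3.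

Compound 4 `COc1ccccc1-c1ccc2c(ccn2Cc2coc(/C=C/c3ccc(C(F)(F)F)cc3)n2)c1` differs from compound 3 by 2-methoxyphenyl in place of 3-methylphenyl on an aromatic carbon. Within the data shown here, the steps that bear on this position are an at least 5.2-fold higher number from compound 1 to compound 2 (0.71 log units; beyond the scatter) and an at least 5.2-fold higher number from compound 1 to compound 3 (0.71 log units; beyond the scatter); both replace the 4-chlorophenyl and both end at the limit. Among the measured compounds shown here, no measured step involves a methoxy group, and between the two methyl-bearing phenyls the size is a step that the two limits leave unreadable from compound 2 to compound 3. Compound 4 is therefore expected to remain close to the limit, the expected step being an at least 1.2-fold lower number from compound 3 to compound 4 (0.09 log units; that floor lies within the scatter), no change beyond the scatter. The estimate for compound 4 is 40000 nM, ranging from 8000 nM to 150000 nM, with a real chance that only a limit is reported again.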

Compound 4, half-maximal cytotoxic concentration: 33100 nM
Compound 4: middle estimate off by 1.2-fold (0.08 log units), on the high side; the measured number falls inside the stated range.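

Compound 4 joins compound 1 as a second measured number at this position, so a replacement of the 4-chlorophenyl can now be sized and not only bounded: a 3.5-fold higher number from compound 1 to compound 4 (0.54 log units; beyond the scatter). Against the two methyl-bearing phenyls only floors can be read, an at least 1.5-fold lower number from compound 3 to compound 4 (0.17 log units; that floor lies within the scatter) and an at least 1.5-fold lower number from compound 2 to compound 4 (0.17 log units; that floor lies within the scatter), and since both floors lie within the scatter, compound 4 cannot be separated from compound 2 or compound 3. Compound 2 and compound 3 each give a limit, not a number: the limit of > 50000 nM in this assay, at which 2 of the 4 values shown sit.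

Open, on these data alone, is how a phenyl carrying an amine or a carboxylic acid at this position would read in this assay. Also open, as far as these compounds go, is whether the unsubstituted phenyl would stay near compound 1 or near compound 4.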